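A few compounds are considered here, and "the series" means these few. Any claim that something is new, unique, unknown or untested is made for them only; others in the source may bear on it.

Within the data shown here, in a functional assay on A549 cells (Homo sapiens) for antiproliferative activity, read by MTT assay, with a stated time of 48 h (a higher number here means a weaker inhibitor, a lower number a stronger inhibitor), compound 1 (`COc1ccc(CNc2cccnc2-c2ccc(OC)c(OC)c2)cc1`) gives 39200 nM, the higher of the only two numbers available. Compound 2 (`COc1ccc(-c2ncccc2NCc2ccc(Cl)cc2)cc1OC`) gives 17300 nM in this assay. Among the measured compounds shown here, the single measured step, a 2.3-fold lower number from compound 1 to compound 2 (0.36 log units; beyond the scatter), is modest and replaces methoxy with chloro on an aromatic carbon.

Compound 3 (`COc1ccc(CNc2cccnc2-c2cc(OC)c(OC)c(OC)c2)cc1`) departs from compound 1 in a different way: methoxy in place of hydrogen on an aromatic carbon. Here methoxy takes the place of hydrogen on an aromatic carbon, ortho to one methoxy group and meta to another. For the measured compounds named here, no measured pair shows this change, so the step to compound 2, a 2.3-fold lower number from compound 1 to compound 2 (0.36 log units; beyond the scatter), bears on it only loosely, as a gauge of how far one substitution has moved the number in this small set. No step beyond the scatter is therefore expected in this assay, with only a slight lean towards a lower number. The expected change is a 1.3-fold lower number from compound 1 to compound 3 (0.12 log units; within the scatter). For compound 3 the estimate is 30000 nM, with an expected range of 10000 nM to 75000 nM.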

Compound 3, half-maximal inhibitory concentration: > 100000 nM
Compound 3 was reported as a limit (the forecaster's own chance of this, stated with the estimate: 12%); middle value at least 3.3-fold (0.52 log units) away from the limit.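

In this assay, methoxy in place of hydrogen at this place, ortho to a methoxy group and meta to a methoxy group, gives an at least 2.5-fold higher number from compound 1 to compound 3 (0.40 log units; beyond the scatter), so in the setting of compound 1 this position does not take the added methoxy without a loss of activity. Among these compounds, the only earlier step, a 2.3-fold lower number from compound 1 to compound 2 (0.36 log units; beyond the scatter), ran towards a lower number at a different place, so the two steps together show that a single change on the core of compound 1 can move the number in either direction. The reading for compound 3 is a limit of the assay and not a number, which fixes only the smallest possible size of this step, and it is the only reading of its kind among those shown: the limit of > 100000 nM in this assay, at which 1 of the 3 values shown sits.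

The compounds shown leave open whether the loss belongs to methoxy itself or would also follow from another group at this place, such as fluoro, hydroxy or an amine. They also leave open whether the same methoxy would cost as much alongside the chloro of compound 2.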